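The source may hold more compounds than are shown below. What is called first, only, known or untested is meant among the compounds shown, and "the series" means these compounds.

In an ADME assay on MT4 cells (Homo sapiens) for cytotoxicity, read by MTT assay (a higher number here means that more compound is tolerated, a lower number that less compound is tolerated), compound 3 `CCc1c(Cc2ccc(Br)cc2)nc(SCc2ccc(OC)cc2)[nH]c1=O` is reported only as a limit of the assay: compound 3 gives > 281000 nM, which is the limit of > 281000 nM in this assay, at which 1 of the 3 values shown sits. Compound 2 `CCc1c(Cc2ccccc2Br)nc(SCc2ccc(OC)cc2)[nH]c1=O` is the one close relative with a plain number, giving 165000 nM in this assay. For the measured compounds named here, the single measured step, an at least 1.7-fold higher number from compound 2 to compound 3 (0.23 log units; that floor lies within the scatter), is the only change followed by numbers, and its size cannot be pinned down beyond its floor. Compound 1 `COc1ccc(CSc2nc(Cc3cc(C)cc(C)c3)c(C)c(=O)[nH]2)cc1` likewise ends at a limit; in this assay compound 1 gives > 329000 nM, which is the limit of > 329000 nM in this assay, at which 1 of the 3 values shown sits. Compound 4 `CCc1c(Cc2cc(C)cc(C)c2)nc(SCc2ccc(OC)cc2)[nH]c1=O` has not yet been measured. It differs from compound 3 by 3,5-dimethylphenyl in place of 4-bromophenyl on a saturated chain carbon bound to an aromatic carbon. Going by the values given here, no measured step covers this exchange, and the two limits in this assay leave no room for a sizeable step to be read from them. The expectation is that compound 4 stays near the top of the range, estimated at 290000 nM, with a span from 150000 nM to 400000 nM. The corresponding step that the limit leaves unreadable from compound 3 to compound 4 is expected to lie within the scatter.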

Compound 4, half-maximal cytotoxic concentration: > 317000 nM
Compound 4 ended at the assay's limit (the forecaster's own chance of this, stated with the estimate: 70%); middle value at least 1.0-fold (0.03 log units) away from the limit.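

With compound 4, a group without bromine sits at a limit of this assay on the saturated chain carbon bound to an aromatic carbon, so the limit seen for compound 3 does not depend on a bromine at this place: the limit of > 317000 nM in this assay, at which 1 of the 4 values shown sits. Against the only plain number in the series, there is an at least 1.9-fold higher number from compound 2 to compound 4 (0.28 log units; that floor lies within the scatter), so the change from 2-bromophenyl to 3,5-dimethylphenyl is not shown to exceed the scatter. The steps to compound 4 from compound 3 and from compound 1 cannot be read, since each joins two limits.

Going by these compounds, how far compound 1, compound 3 and compound 4 lie past their limits stays open. Also open, on these data alone, is whether a phenyl carrying an amine or a carboxylic acid at this place would give a plain number in this assay.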